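Semicarbazone aryl swap: hydroxynaphthyl replacing dimethoxyphenyl

The source may report more compounds than this note shows. Statements on the series, on what has been measured and on what is new or still open speak of the compounds shown alone.

Compound 2 `COc1ccc(/C=N/NC(=O)Nc2ccc(Oc3ccnc(-c4nncn4CCN(C)C)c3)c(F)c2)c(OC)c1` gives 2820 nM in a functional assay on A549 cells (Homo sapiens) for cytotoxicity, read by MTT assay, with a stated time of 72 h (a higher number here means a weaker inhibitor, a lower number a stronger inhibitor), the highest of the three numbers; compound 3 `CN(C)CCn1cnnc1-c1cc(Oc2ccc(NC(=O)N/N=C/c3ccc(F)cc3F)cc2F)ccn1` gives 1870 nM and compound 1 `CN(C)CCn1cnnc1-c1cc(Oc2ccc(NC(=O)N/N=C/c3ccc(Cl)cc3Cl)cc2F)ccn1` gives 810 nM. Compound 4 `CN(C)CCn1cnnc1-c1cc(Oc2ccc(NC(=O)N/N=C/c3c(O)ccc4ccccc34)cc2F)ccn1` differs from compound 2 by 2-hydroxynaphthalen-1-yl in place of 2,4-dimethoxyphenyl on a carbon with a double bond to nitrogen. The measured steps on that same carbon are a 3.5-fold higher number from compound 1 to compound 2 (0.54 log units; beyond the scatter), a 2.3-fold higher number from compound 1 to compound 3 (0.36 log units; beyond the scatter) and a 1.5-fold lower number from compound 2 to compound 3 (0.18 log units; within the scatter); only the dichlorophenyl-bearing compound 1 moves beyond the scatter, and every ring tried so far is a single six-membered ring. Among the measured compounds shown here, no step adds a second fused ring or a hydroxyl, so the expectation leans on the spread already seen rather than a direct precedent. For compound 4 a modest drop in number is expected, a 1.9-fold lower number from compound 2 to compound 4 (0.27 log units; within the scatter), giving an estimated 1500 nM with a range of 500 nM to 4500 nM.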

Compound 4, half-maximal inhibitory concentration: 880 nM
Compound 4: middle estimate off by 1.7-fold (0.23 log units), on the high side; low and high end bracket the measured number.
By their numbers in this assay, from the lowest: compounds 1 and 4 (each within the scatter of the next); then compounds 3 and 2 (each within the scatter of the next).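

In this assay, the step to a fused ring system bearing a hydroxyl lowers the number relative to both single rings without chlorine (a 3.2-fold lower number from compound 2 to compound 4 (0.51 log units; beyond the scatter); a 2.1-fold lower number from compound 3 to compound 4 (0.33 log units; beyond the scatter)). Against 2,4-dichlorophenyl, 2-hydroxynaphthalen-1-yl cannot be told apart (a 1.1-fold higher number from compound 1 to compound 4 (0.04 log units; within the scatter)), so two quite different aryl groups on this carbon give matching numbers. Nothing measured here accounts for this result.

The compounds shown do not separate the hydroxyl from the second ring. A naphthalen-1-yl without the hydroxyl, or a 2-hydroxyphenyl, would divide the two.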